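The source may hold more compounds than are shown below. What is called first, only, known or untested is meant among the compounds shown, and "the series" means these compounds.

Measured so far:
- Compound 1 `COc1ccc(-c2cc3ccccc3nc2/C=C/C(=O)c2ccc(OC)c(OC)c2)cc1`: 4790 nM
- Compound 2 `COc1ccc(-c2cc3ccccc3nc2/C=C/C(=O)c2ccc([N+](=O)[O-])cc2)cc1`: 840 nM

Among the compounds with values here, compound 2 holds the lowest of the two numbers measured in a functional assay on MDA-MB-231 cells (Homo sapiens) for antiproliferative activity, read by XTT assay, with a stated time of 72 h; on this read-out higher numbers stand for weaker inhibition and lower numbers for stronger inhibition; compound 1 gives 4790 nM and compound 2 gives 840 nM, and the only measured step, a 5.7-fold lower number from compound 1 to compound 2 (0.76 log units; beyond the scatter), lies beyond the scatter. Both compounds share the same core and differ only in the aromatic group attached to the carbonyl carbon.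

Compound 3 `COc1ccc(-c2cc3ccccc3nc2/C=C/C(=O)c2ccccn2)cc1` has not yet been measured in this assay. It differs from compound 2 in that place: pyridin-2-yl in place of 4-nitrophenyl on a carbonyl carbon. Within the data shown here, the one step that bears on this change is the earlier swap on the same carbonyl carbon, a 5.7-fold lower number from compound 1 to compound 2 (0.76 log units; beyond the scatter), which shows that exchanging the aryl group there moves the number by a modest amount. Whether the new group behaves like 4-nitrophenyl or like 3,4-dimethoxyphenyl cannot be told from two compounds, so the estimate leans toward the middle of the measured span, a move of a 3.0-fold higher number from compound 2 to compound 3 (0.47 log units; beyond the scatter) toward a higher number. Compound 3 is therefore expected to give about 2500 nM, with a likely range from 700 nM to 9000 nM.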

Compound 3, half-maximal inhibitory concentration: 740 nM
Estimate against measurement, compound 3: 3.4-fold (0.53 log units) above, within the range that was stated.
By their numbers in this assay, from the lowest: compounds 3 and 2 (each within the scatter of the next); then compound 1.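

Replacing 4-nitrophenyl with pyridin-2-yl on the carbonyl carbon gives a 1.1-fold lower number from compound 2 to compound 3 (0.06 log units; within the scatter) in this assay and so leaves the read-out within the usual scatter, even though pyridin-2-yl has fewer heavy atoms, carries a nitrogen in its ring and has no nitro group. Replacing 3,4-dimethoxyphenyl with pyridin-2-yl gives a 6.5-fold lower number from compound 1 to compound 3 (0.81 log units; beyond the scatter) and shows that the gain seen with 4-nitrophenyl is not tied to that one group, since two quite different aromatic groups now sit well apart from compound 1 and level with each other. Nothing measured here explains why these three groups fall as they do.

Still open, from the compounds shown here alone, is how a plain phenyl group, a pyridin-4-yl group or a saturated amine such as piperidine would read on this same carbonyl carbon, and so whether any aromatic group lacking the two methoxy groups would match compound 2 and compound 3. Also open, going by these compounds, is whether this picture would hold with a different group in place of the 4-methoxyphenyl shared by all three compounds, such as a carboxylic acid on that ring.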